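Swapping the aryl amide group in a thiazole-urea series

The source may hold more compounds than are shown below. What is called first, only, known or untested is meant among the compounds shown, and "the series" means these compounds.

For the measured compounds named here, in an ADME assay on the whole organism (strain Han-Wistar) for pharmacokinetics, with Rattus norvegicus as the target, read by LC-MS, at a dose of 2 mg/kg by the oral route (on this read-out lower numbers stand for lower exposure and higher numbers for higher exposure at the dose given), compound 2 `CN1CCN(CCCS(=O)(=O)c2ccc3nc(NC(=O)NC(=O)c4cc5c(ccn5C)cc4Cl)sc3c2)CC1` gives 300 nM, the lowest of the two numbers known, while compound 1 `CCOc1ccc(Cl)c(C(=O)NC(=O)Nc2nc3ccc(S(=O)(=O)CCCN4CCN(C)CC4)cc3s2)c1` gives 4200 nM. Compound 3 `CN1CCN(CCCS(=O)(=O)c2ccc3nc(NC(=O)NC(=O)c4cc(-n5cccn5)ccc4Cl)sc3c2)CC1` carries 2-chloro-5-(1H-pyrazol-1-yl)phenyl in place of 5-chloro-1-methyl-1H-indol-6-yl on a carbonyl carbon. Going by the values given here, the only step that bears on it is a 14-fold lower number from compound 1 to compound 2 (1.15 log units; beyond the scatter), where a change at the same carbonyl carbon moved exposure strongly. Compound 3 returns to a chlorophenyl bearing a five-membered ring, so compound 3 is expected to land between those two values, at 1000 nM with a range of 250 nM to 4000 nM, an expected 3.3-fold higher number from compound 2 to compound 3 (0.52 log units; beyond the scatter).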

Compound 3, maximal plasma concentration: 1200 nM
Beside the measured number, compound 3's estimate is 1.2-fold (0.08 log units) below it, within the range that was stated.
By their numbers in this assay, from the lowest: compound 2; then compound 3; then compound 1.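

With the chlorophenyl kept, putting 1H-pyrazol-1-yl in place of ethoxy on an aromatic carbon gives a 3.5-fold lower number from compound 1 to compound 3 (0.54 log units; beyond the scatter) in this assay, so a change at this one group alone lowers exposure. Replacing 5-chloro-1-methyl-1H-indol-6-yl with 2-chloro-5-(1H-pyrazol-1-yl)phenyl gives a 4.0-fold higher number from compound 2 to compound 3 (0.60 log units; beyond the scatter) and thus recovers only part of the earlier loss, which shows that this position gives intermediate values as well as extremes. Nothing available explains either step. As far as these compounds go, whether a methoxy group or an amine in place of ethoxy would keep the exposure of compound 1 remains open.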